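The source may hold more compounds than are shown below. What is called first, only, known or untested is meant among the compounds shown, and "the series" means these compounds.

Compound 1 `CCN(c1ccc(C#N)c(Cl)c1)c1cc(-c2ccoc2)ccc1C` gives in a functional assay on VCaP cells (Homo sapiens) for antiproliferative activity, read by CCK-8 assay, with a stated time of 6 days (a lower number here means a stronger inhibitor, a higher number a weaker inhibitor), a value of 4010 nM.
Compound 2 `CCN(c1ccc(C#N)c(Cl)c1)c1cc(-c2ccccc2)ccc1C` gives in this assay only the limit > 30000 nM.
Compound 3 `CCN(c1ccc(C#N)c(Cl)c1)c1cc(-c2ccco2)ccc1C` gives in this assay only the limit > 30000 nM.

Compound 3 therefore stands at the weak end of what these numbers show: its value is not a number but the limit of the method, and the limit of > 30000 nM in this assay, at which 2 of the 3 values shown sit, means that compound 2 sits at the same place, so the two cannot be told apart. Within the data shown here, the only measurable compound is compound 1, and the step of an at least 7.4-fold higher number from compound 1 to compound 3 (0.87 log units; beyond the scatter) shows that moving the furan attachment point cost potency.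

Compound 4 `CCN(c1ccc(C#N)c(Cl)c1)c1cc(-c2c[nH]nc2C)ccc1C` is the next compound, and it differs from compound 3 in one place: 3-methyl-1H-pyrazol-4-yl in place of furan-2-yl on an aromatic carbon. The step of an at least 7.4-fold higher number from compound 1 to compound 3 (0.87 log units; beyond the scatter) is the one that bears on it most directly. It shows that the identity and attachment of this five-membered ring matters in this assay. The step that the two limits leave unreadable from compound 2 to compound 3 adds nothing readable, and an at least 7.4-fold higher number from compound 1 to compound 2 (0.87 log units; beyond the scatter) shows that a plain phenyl is also weak.

The pyrazole of compound 4 is joined through the same kind of position as the furan-3-yl of compound 1, so compound 4 is expected to move back toward measurable potency, with an estimated step of an at least 5.0-fold lower number from compound 3 to compound 4 (0.69 log units; beyond the scatter). For compound 4 the estimate is 6000 nM, with a range from 1500 nM to 30000 nM.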

Compound 4, half-maximal inhibitory concentration: 3190 nM
For compound 4 the middle estimate is 1.9-fold (0.27 log units) above the measured one; the measured number falls inside the stated range.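

In this assay, the position para to a methyl group turns out to tolerate more than one ring: with 3-methyl-1H-pyrazol-4-yl there, the data show an at least 9.4-fold lower number from compound 3 to compound 4 (0.97 log units; beyond the scatter), and also an at least 9.4-fold lower number from compound 2 to compound 4 (0.97 log units; beyond the scatter). Until now only the furan-3-yl of compound 1 had given a real number at this position, but the data now show a 1.3-fold lower number from compound 1 to compound 4 (0.10 log units; within the scatter), so two different five-membered aromatic rings cannot be told apart here, and a readable result is not tied to the furan alone. Compound 2 and compound 3 still give only a limit of the assay, not a number: the limit of > 30000 nM in this assay, at which 2 of the 4 values shown sit.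

The compounds shown do not separate the contribution of the methyl group of compound 4 from that of its pyrazole ring, or show whether the ring's hydrogen on nitrogen matters to the result. As far as these compounds go, it also stays open how this position would respond to a quite different group, such as an amine, a carboxylic acid or a longer chain in place of the ring.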